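From Phenyl to sec-Butyl at the Assay Limit

The source may report more compounds than this note shows. Statements on the series, on what has been measured and on what is new or still open speak of the compounds shown alone.

Compound 1 `CCC(C)C(NC(=O)n1nnc2ccccc21)C(=O)NC1CCCCC1` gives 57900 nM in a functional assay on HEp-2 cells (Homo sapiens) for inhibition; a lower number here means a stronger inhibitor, a higher number a weaker inhibitor.
Compound 2 `O=C1NC(c2ccccc2)C(=O)N1C1CCCC1` gives only a limit, > 100000 nM, in this assay.
Compound 3 `CCC(C)C(NC(=O)NO)C(=O)NC1CCCC1` also gives only a limit, > 100000 nM, in this assay.

Compound 2 therefore stands at the edge of what this assay can report: its value is a limit and not a number, and it shares (the limit of > 100000 nM in this assay, at which 2 of the 3 values shown sit). Only compound 1 gives a real number, and that number is weak. Compound 4 `CCC(C)C1NC(=O)N(C2CCCC2)C1=O` has not yet been measured. It differs from compound 2 in one place: sec-butyl in place of phenyl on a saturated ring carbon. Within the data shown here, no measured pair shows a change of this kind, and the size of the step can only be estimated. The sec-butyl group also appears in compound 1 and in compound 3, and neither of those is a strong inhibitor, though both differ from compound 4 in further places. Compound 4 is expected to stay weak, with an expected step of a number no higher from compound 2 to compound 4 (the limit leaves the size open) that is no larger than the scatter. Compound 4 is estimated at 100000 nM, between 30000 nM and 300000 nM, and this assay will quite possibly again report only a limit.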

Compound 4, half-maximal inhibitory concentration: > 100000 nM
Compound 4: only a limit was reported; the forecaster's own chance of this, stated with the estimate: 60%; the middle value lies on the limit itself.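

Among these compounds, compound 2 and compound 4 each give only a limit and not a number, and no step between them can be read in this assay. The compounds shown leave open whether phenyl or sec-butyl on this saturated ring carbon gives the stronger inhibitor.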